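This account rests on a few compounds, and the source may have more. Where it says the series, first, only, none or still open, it means among the compounds named here.

Working notes on the pyridin-3-yl thiourea series. In an assay on membranes from brain for binding affinity to Lysophosphatidylserine lipase ABHD12 (Mus musculus), read by fluorescence, with a stated time of 20 min (a higher number here means a weaker inhibitor, a lower number a stronger inhibitor), compound 2 `Cc1c(Oc2ccc(OC(F)(F)F)cc2)ccnc1N1CCC(NC(=S)Nc2cccnc2)CC1` gives 26 nM, while compound 1 `FC(F)(F)Oc1ccc(Oc2ccnc(N3CCC(NC(=S)Nc4cccnc4)CC3)c2)cc1` gives 410 nM. The change between them, (hydrogen in place of methyl on an aromatic carbon), produced a 16-fold higher number from compound 2 to compound 1 (1.20 log units; beyond the scatter). Compound 3 `Cc1cnc(N2CCC(NC(=S)Nc3cccnc3)CC2)c(Cl)c1` carries a different core; the difference between the cores of compound 3 and compound 2 is not broken down here. In this assay compound 3 gives 3100 nM, the highest of the three numbers. Compound 4 `S=C(Nc1cccnc1)NC1CCN(c2ncccc2Cl)CC1` is not yet measured; it differs from compound 3 by hydrogen in place of methyl on an aromatic carbon. The surroundings differ: in compound 2 the methyl sits ortho to two large groups, in compound 3 meta to a chloro group and para to a large group, so this is the same kind of change, not the same. Resting on the single earlier step of a 16-fold higher number from compound 2 to compound 1 (1.20 log units; beyond the scatter), a step of a 6.5-fold higher number from compound 3 to compound 4 (0.81 log units; beyond the scatter) is expected. Compound 4 is estimated at 20000 nM, within 6000 nM to 70000 nM.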

Compound 4, half-maximal inhibitory concentration: > 5000 nM
Compound 4 ended at the assay's limit; the forecaster's own chance of this, stated with the estimate: 25%; the middle value is on the limit's open side.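

Compound 4 gives > 5000 nM, which is a limit of the assay and not a number. Hydrogen in place of methyl gives an at least 1.6-fold higher number from compound 3 to compound 4 (0.20 log units; that floor lies within the scatter), so this result does not go against the direction seen on the other core, but on its own it does not establish a real loss on the core of compound 3. What carries over in size therefore remains unread: the same change on two cores in this assay, a 16-fold higher number (1.20 log units; beyond the scatter) from compound 2 to compound 1 and an at least 1.6-fold higher number (0.20 log units; that floor lies within the scatter) from compound 3 to compound 4; the limit leaves it open whether they differ

The compounds shown leave open how large the step on the core of compound 3 really is. They also leave open what an ethyl group or an amine in the place of the methyl would give on either core.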